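The source may report more compounds than this note shows. Statements on the series, on what has been measured and on what is new or still open speak of the compounds shown alone.

Values measured in a functional assay on Huh-5-2 cells (Homo sapiens) for cytotoxicity, read by microscopy (on this read-out higher numbers stand for lower toxicity in this test and lower numbers for higher toxicity in this test), are these.
- compound 1 (`O=c1oc2ccccc2cc1CSc1nc2cncnc2n1[C@@H]1O[C@H](CO)[C@@H](O)[C@H]1O`) gives 50000 nM
- compound 2 (`Nc1ncnc2c1nc(SCc1cc3ccccc3oc1=O)n2[C@@H]1O[C@H](CO)[C@@H](O)[C@H]1O`) gives 49000 nM

Compound 2 stands level with compound 1, as the two values lie within the scatter of each other. Compound 3 (`Nc1ncnc2c1nc(SCc1cc3cc(Br)ccc3oc1=O)n2[C@@H]1O[C@H](CO)[C@@H](O)[C@H]1O`) has bromo in place of hydrogen on an aromatic carbon of compound 2 (bromo in place of hydrogen on an aromatic carbon). Among the compounds with values here, the only measured step (a 1.0-fold lower number from compound 1 to compound 2 (0.01 log units; within the scatter)) is within the scatter, but it introduces amino, and no bromo compound has been measured, so it offers only weak guidance. No step beyond the scatter is therefore expected in this assay and the estimated step is small (a 1.4-fold lower number from compound 2 to compound 3 (0.15 log units; within the scatter)). For compound 3 the expected value is 35000 nM (estimated range 12000 nM to 70000 nM).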

Compound 3, half-maximal cytotoxic concentration: 41000 nM
Estimate against measurement, compound 3: 1.2-fold (0.07 log units) below; low and high end bracket the measured number.
By their numbers in this assay, from the lowest: compounds 3, 2 and 1 (each within the scatter of the next).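

In this assay, bromo in place of hydrogen on an aromatic carbon of the six-membered ring of carbon only gives a 1.2-fold lower number from compound 2 to compound 3 (0.08 log units; within the scatter), so compound 3 stands level with compound 2. Within the data shown here, the earlier step concerned amino at another place, so this is the first reading at this position: a single bromine atom here brings no step beyond the scatter. No measurement at hand explains this result. Open, from the compounds shown here alone, is whether a carboxylic acid or an amine at this same carbon would also stay level, and whether bromo on the other carbons of this ring would.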